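Aromatic-nitrogen substituent swap on the shared core

The source may hold more compounds than are shown below. What is called first, only, known or untested is meant among the compounds shown, and "the series" means these compounds.

Measured compounds:
Compound 1 `CN1C(=S)[C@@H](NC(=O)c2nc(Cc3ccccc3)n(CCCF)n2)COc2ccccc21` gives in a toxicity assay on HT-29 cells (Homo sapiens) for cytotoxicity (on this read-out lower numbers stand for higher toxicity in this test and higher numbers for lower toxicity in this test), only the limit > 100000 nM.
Compound 2 `CN1C(=S)[C@@H](NC(=O)c2nc(Cc3ccccc3)n(CC3CCOCC3)n2)COc2ccccc21` gives in this assay only the limit > 100000 nM.

Compound 1 therefore stands at the limit of > 100000 nM in this assay, at which 2 of the 2 values shown sit, with no number of its own. Going by the values given here, the single measured step, a step that the two limits leave unreadable from compound 1 to compound 2, is unreadable in size. Compound 3 `CN1C(=S)[C@@H](NC(=O)c2nc(Cc3ccccc3)n(-c3ncccn3)n2)COc2ccccc21` differs from compound 1 by pyrimidin-2-yl in place of 3-fluoropropyl on an aromatic nitrogen. Among the compounds with values here, no measured step bears on this change with a readable size, so nothing beyond the scatter is expected in this assay. Compound 3 is expected at 100000 nM, within 30000 nM to 300000 nM, an expected step of a number no higher from compound 1 to compound 3 (the limit leaves the size open).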

Compound 3, half-maximal cytotoxic concentration: > 100000 nM
Compound 3: only a limit was reported; the forecaster's own chance of this, stated with the estimate: 85%; the middle value lies on the limit itself.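

No step can be read among compound 1, compound 2 and compound 3 in this assay, as all three are reported only as limits: the limit of > 100000 nM in this assay, at which 3 of the 3 values shown sit.

The compounds shown leave open whether 3-fluoropropyl, (oxan-4-yl)methyl and pyrimidin-2-yl differ at all in this assay.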